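Triazole Aryl Swaps on a Terpenoid Ester: Cytotoxicity

The source may hold more compounds than are shown below. What is called first, only, known or untested is meant among the compounds shown, and "the series" means these compounds.

Measured in an ADME assay on L132 cells (Homo sapiens) for cytotoxicity, read by MTT assay, with a stated time of 48 h; on this read-out higher numbers stand for weaker inhibition and lower numbers for stronger inhibition:
- compound 1 `C/C(=C\CC/C(C)=C/CC[C@@H]1[C@@]2(C)CCC(=O)C(C)(C)[C@H]2CC[C@@]1(C)O)CC/C=C(\C)C(=O)OCc1cn(-c2ccc(C(F)(F)F)cc2)nn1`: > 150000 nM, a limit rather than a number
- compound 2 `C/C(=C\CC/C(C)=C/CC[C@@H]1[C@@]2(C)CCC(=O)C(C)(C)[C@H]2CC[C@@]1(C)O)CC/C=C(\C)C(=O)OCc1cn(-c2ccccc2[N+](=O)[O-])nn1`: > 150000 nM, likewise a limit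
- compound 3 `C/C(=C\CC/C(C)=C/CC[C@@H]1[C@@]2(C)CCC(=O)C(C)(C)[C@H]2CC[C@@]1(C)O)CC/C=C(\C)C(=O)OCc1cn(-c2cccc(Br)c2)nn1`: > 150000 nM, likewise a limit

Compound 1 stands at the limit of > 150000 nM in this assay, at which 3 of the 3 values shown sit, so its place among the three is not a measured number but the edge of this assay. The new compound 4 `C/C(=C\CC/C(C)=C/CC[C@@H]1[C@@]2(C)CCC(=O)C(C)(C)[C@H]2CC[C@@]1(C)O)CC/C=C(\C)C(=O)OCc1cn(-c2cccc(Cl)c2)nn1` differs from compound 1 by 3-chlorophenyl in place of 4-(trifluoromethyl)phenyl on an aromatic nitrogen. Going by the values given here, two measured steps bear on this change, as each replaces the same group on the same aromatic nitrogen: a step that the two limits leave unreadable from compound 1 to compound 2 and a step that the two limits leave unreadable from compound 1 to compound 3. A third, a step that the two limits leave unreadable from compound 2 to compound 3, compares two of those replacements with each other. None of these steps gives a readable size, because every value sits at the limit of > 150000 nM in this assay, at which 3 of the 3 values shown sit. No step beyond the scatter is therefore expected in this assay for compound 4, and its result is estimated to be a limit again. The expected step is a number no higher from compound 1 to compound 4 (the limit leaves the size open). Compound 4 is estimated at 150000 nM, within a range from 80000 nM to 400000 nM.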

Compound 4, half-maximal inhibitory concentration: 94200 nM
For compound 4 the middle estimate is 1.6-fold (0.20 log units) above the measured one; the range from low to high includes it.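

In this assay, going by these compounds alone, compound 4, which carries 3-chlorophenyl on the aromatic nitrogen, gives 94200 nM, the only value of the four that is a number and not a limit. This gives each step into compound 4 a floor, though not a full size: an at least 1.5-fold lower number from compound 1 to compound 4 (0.20 log units; that floor lies within the scatter), an at least 1.5-fold lower number from compound 3 to compound 4 (0.20 log units; that floor lies within the scatter) and an at least 1.5-fold lower number from compound 2 to compound 4 (0.20 log units; that floor lies within the scatter). As each floor lies within the scatter, even the change of bromo to chloro cannot yet be said to matter, and the steps among compound 1, compound 2 and compound 3 remain unreadable because all three values are limits: the limit of > 150000 nM in this assay, at which 3 of the 4 values shown sit.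

The compounds shown leave open how large these steps really are. They also leave open how an amine or a carboxylic acid on the phenyl ring would read in this assay.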